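This account rests on a few compounds, and the source may have more. Where it says the series, first, only, none or still open, it means among the compounds named here.

Of the compounds shown here, two have been measured in a functional assay on A549 cells (Homo sapiens) for antiproliferative activity, read by MTT assay, with a stated time of 72 h; a higher number here means a weaker inhibitor, a lower number a stronger inhibitor. Compound 1 `Cc1nc(C)c(/C=C/C(=O)/C=C/c2ccc(F)cc2)nc1C` gives 5900 nM, and compound 2 `Cc1ccc(/C=C/C(=O)/C=C/c2nc(C)c(C)nc2C)cc1` gives 4300 nM. Compound 2 therefore stands within the scatter of compound 1, and the two numbers do not separate. The next compound is compound 3 `Cc1nc(C)c(/C=C/C(=O)/C=C/c2ccc([N+](=O)[O-])cc2)nc1C`, which has nitro in place of methyl on an aromatic carbon, para to a large group: nitro in place of methyl on an aromatic carbon. For the measured compounds named here, only one measured step bears on this change. It concerns the same aromatic carbon, with methyl in place of fluoro, and amounts to a 1.4-fold lower number from compound 1 to compound 2 (0.14 log units; within the scatter). Going by the values given here, no nitro compound has been measured, so that single small step is a thin guide and the range has to stay wide. On the strength of this step, a 1.4-fold lower number from compound 1 to compound 2 (0.14 log units; within the scatter), no shift beyond the scatter is expected in this assay, and no direction can be favoured. The expected change is a 1.0-fold higher number from compound 2 to compound 3 (0.02 log units; within the scatter). Compound 3 is estimated at 4500 nM, with an expected range of 1500 nM to 12000 nM.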

Compound 3, half-maximal inhibitory concentration: 9600 nM
Compound 3: the middle estimate sits 2.1-fold (0.33 log units) below what was measured; measured number inside the range.
By their numbers in this assay, from the lowest: compounds 2, 1 and 3 (each within the scatter of the next, the first and the last beyond it).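

For the compounds shown here, at this aromatic carbon, nitro in place of methyl gives the first step beyond the scatter in this assay: a 2.2-fold higher number from compound 2 to compound 3 (0.35 log units; beyond the scatter), a modest shift towards a weaker inhibitor, which shows that the position is not wholly indifferent to the group it carries. Nitro in place of fluoro does not separate the compounds, with a 1.6-fold higher number from compound 1 to compound 3 (0.21 log units; within the scatter), so fluoro cannot be placed apart from either methyl or nitro, and only methyl and nitro are distinguished at this position, on the strength of this single modest step. No measurement on hand bears on the origin of the shift, and the numbers record its size and direction only.

Going by these compounds, whether an amine, a carboxylic acid, a methoxy group or plain hydrogen on the same carbon would fall with methyl, with nitro or outside that span remains open. On these data alone, the three compounds also share one core and vary at one position, so it is unknown whether the step between methyl and nitro would hold on a changed core or with the group placed elsewhere on the ring.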